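Trimming the Chain on the Nitrogen: What Compound 4 Might Show

The source may report more compounds than this note shows. Statements on the series, on what has been measured and on what is new or still open speak of the compounds shown alone.

Three compounds with a shared core differ only in the chain attached to the aromatic nitrogen. Compound 1 `CCCn1c(-c2ccc(O)c(O)c2)c(C)c2cc(O)ccc21` carries a plain propyl chain, and in a functional assay on A2780 cells (Homo sapiens) for inhibition, read by trypan blue exclusion, with a stated time of 72 h (a lower number here means a stronger inhibitor of growth, a higher number a weaker inhibitor of growth), compound 1 gives 8400 nM. Compound 2 `Cc1c(-c2ccc(O)c(O)c2)n(CCCCOc2ccccc2)c2ccc(O)cc12` carries a longer chain ending in a phenoxy group, and in this assay compound 2 gives 4300 nM. Compound 3 `Cc1c(-c2ccc(O)c(O)c2)n(CCCOc2ccccc2)c2ccc(O)cc12` carries a shorter chain ending in the same group, and in this assay compound 3 gives 7400 nM. Among these three numbers compound 3 stands second highest, and its gaps to the other two fall within the scatter: a 1.1-fold lower number from compound 1 to compound 3 (0.06 log units; within the scatter) and a 1.7-fold higher number from compound 2 to compound 3 (0.24 log units; within the scatter).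

Compound 4 `Cc1c(-c2ccc(O)c(O)c2)n(C)c2ccc(O)cc12` cuts the chain back almost entirely: hydrogen in place of 2-phenoxyethyl on a saturated chain carbon bound to an aromatic nitrogen. For the measured compounds named here, no measured step shortens the chain below propyl, so the expectation rests on what the chain end did. Those steps were a 2.0-fold lower number from compound 1 to compound 2 (0.29 log units; within the scatter) and a 1.1-fold lower number from compound 1 to compound 3 (0.06 log units; within the scatter), both within the scatter, which suggests the tail contributed little in this assay. The step of a 1.2-fold higher number from compound 3 to compound 4 (0.09 log units; within the scatter) is therefore expected to be small, with a slight lean toward a higher number. Compound 4 is estimated at 9000 nM in this assay, within a range of 3000 nM to 27000 nM.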

Compound 4, concentration for 50% growth inhibition: 14000 nM
The estimate for compound 4 lay 1.6-fold (0.19 log units) below the measured number; the measured number falls inside the stated range.
By their numbers in this assay, from the lowest: compounds 2, 3, 1 and 4 (each within the scatter of the next, the first and the last beyond it).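

For the compounds shown here, replacing 3-phenoxypropyl with hydrogen gives the first step at this position that clears the scatter in this assay: a 3.3-fold higher number from compound 2 to compound 4 (0.51 log units; beyond the scatter), a modest change. The other two steps, a 1.9-fold higher number from compound 3 to compound 4 (0.28 log units; within the scatter) and a 1.7-fold higher number from compound 1 to compound 4 (0.22 log units; within the scatter), stay within the scatter, so the losses of 2-phenoxyethyl and of ethyl cannot be told apart from the normal spread of repeated measurements. The chain on the nitrogen therefore matters to a small degree at most, and the single clear gap lies only between compound 2 and compound 4, with nothing in the data explaining that gap.

As far as these compounds go, all four compounds carry either a plain carbon chain or a chain ending in phenoxy, so it remains open what an amine or a carboxylic acid at the end of the chain would do, or a chain longer than 3-phenoxypropyl. The hydroxyl groups of the shared core are also the same throughout, which leaves open how a methoxy group in place of any of them would alter these numbers.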